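Working notes on amine variation within the shared core

This account rests on a few compounds, and the source may have more. Where it says the series, first, only, none or still open, it means among the compounds named here.

Two compounds of the series carry numbers in an assay on CHO cells for displacement of a labelled ligand from 5-hydroxytryptamine receptor 1D (Homo sapiens); on this read-out lower numbers stand for stronger inhibition and higher numbers for weaker inhibition. Compound 1, `OC[C@H](NC1CCN(CCCc2c[nH]c3ccc(-n4ccnc4)cc23)CC1)c1ccccc1`, gives 0.7 nM. Compound 2, `CN(Cc1cccs1)C1CCN(CCCc2c[nH]c3ccc(-n4cnnc4)cc23)CC1`, gives 4.3 nM, which is the higher of the two numbers and stands apart from compound 1 by a gap that lies beyond the usual scatter. For the measured compounds named here, the two differ in more than one place, so no single step between them is counted.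

Compound 3, `c1ccc(CNC2CCN(CCCc3c[nH]c4ccc(-n5cnnc5)cc34)CC2)cc1`, has not been measured in this assay. It is compound 2 with benzylamino in place of methyl((thiophen-2-yl)methyl)amino on a saturated ring carbon. The incoming group restores a hydrogen-bond donor at that carbon, a feature that compound 1 shares and that goes with its lower number, though the cores of compound 1 and compound 3 are not identical, so the comparison is loose.

On this basis a modest downward step is expected from compound 2 to compound 3, a 2.2-fold lower number from compound 2 to compound 3 (0.33 log units; beyond the scatter), with the possibility that the change stays within the scatter. The estimated value for compound 3 in this assay is 2 nM, with a plausible range from 0.6 nM to 6.5 nM.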

Compound 3, half-maximal inhibitory concentration: 4.6 nM
Beside the measured number, compound 3's estimate is 2.3-fold (0.36 log units) below it; low and high end bracket the measured number.
By their numbers in this assay, from the lowest: compound 1; then compounds 2 and 3 (each within the scatter of the next).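

In this assay, for the compounds shown here, benzylamino in place of methyl((thiophen-2-yl)methyl)amino on a saturated ring carbon gives a 1.1-fold higher number from compound 2 to compound 3 (0.03 log units; within the scatter), the first step that can be read at a single place. The change swaps a five-membered aromatic ring with 1 hetero atom for a six-membered aromatic ring of carbon only and brings in a hydrogen-bond donor, yet taken together these differences leave the two compounds indistinguishable on this read-out, so the hydrogen-bond donor alone does not mark out a separate level at this position within this pair. Nothing measured here offers an explanation for this result.

Going by these compounds, whether the ring swap and the hydrogen-bond donor each leave the number alone or instead offset one another remains open, and methyl(benzyl)amino or (thiophen-2-yl)methylamino on the same carbon would separate the two. Also open, on these data alone, is the source of the gap to compound 1 at 0.7 nM, since compound 1 differs from compound 2 and from compound 3 in more than one place.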